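The compounds below may be only part of what the source reports. "The series", "measured", "known", "first", "only" and "open" are said of these compounds alone.

Measured compounds:
- compound 1, `C=C1CC[C@H]2[C@](C)(CO)CCC[C@]2(C)[C@H]1C[C@]12O[C@H]1[C@@H](O)C(CO)=C(Cl)C2=O`, 7900 nM in a functional assay on HeLa cells (Homo sapiens) for inhibition, read by MTT assay, with a stated time of 72 h; a higher number here means a weaker inhibitor, a lower number a stronger inhibitor
- compound 2, `C=C1CC[C@H]2[C@](C)(CO)CCC[C@]2(C)[C@H]1C[C@]12O[C@H]1[C@@H](O)C(CO)=CC2=O`, 29300 nM in this assay

Compound 2 gives the highest number of the two, which means the weaker inhibition: compound 1 is nearest, and the step of a 3.7-fold higher number from compound 1 to compound 2 (0.57 log units; beyond the scatter) is the only one available, from exchanging a chloro on a double-bonded ring carbon for hydrogen.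

Compound 3, `C=C1CC[C@H]2[C@](C)(CO)CCC[C@]2(C)[C@H]1C[C@@]12O[C@@H]1[C@@H](O)C(CO)=CC2=O`, is not yet measured. It is built from compound 2 by a change of configuration alone: the two compounds have the same atoms and bonds and differ only in configuration as drawn: 2 of 7 stereo elements differ; a stereocentre at a saturated ring carbon is drawn S in compound 2 and R in compound 3; a stereocentre at a saturated ring carbon is drawn S in compound 2 and R in compound 3

For the measured compounds named here, the one measured step, from chloro to hydrogen, changes the atoms present, whereas the step from compound 2 to compound 3 changes only how two saturated ring carbons are arranged in space. Going by the values given here, no measured pair shows what such a change does here, so the expectation for compound 3 cannot rest on a comparable step, and no direction can be called. The estimate for compound 3 in this assay is therefore placed near the value of compound 2, as a step of a 1.0-fold lower number from compound 2 to compound 3 (0.00 log units; within the scatter) with a wide range: the expected value is 29000 nM, between 7000 nM and 120000 nM.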

Compound 3, half-maximal inhibitory concentration: 35900 nM
The estimate for compound 3 lay 1.2-fold (0.09 log units) below the measured number, and the stated range covers the measured number.
By their numbers in this assay, from the lowest: compound 1; then compounds 2 and 3 (each within the scatter of the next).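

In this assay, for the compounds shown here, the step of a 1.2-fold higher number from compound 2 to compound 3 (0.09 log units; within the scatter) is the only measured change of configuration here, and it stays within the usual scatter. With hydrogen on the double-bonded ring carbon, changing the drawn configuration at the two saturated ring carbons therefore gives no measurable difference, and the comparison is direct because nothing else separates the pair: the fact that compounds 2 and 3 differ only in the configuration as drawn So the configuration drawn in compound 2 at these two carbons is not required for the level of inhibition seen with this hydrogen-bearing pair, while the step of a 3.7-fold higher number from compound 1 to compound 2 (0.57 log units; beyond the scatter), from chloro to hydrogen, remains the only one beyond the scatter.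

Both carbons change together, so these compounds cannot show what either change does alone, or whether two separate effects offset each other. Going by these compounds, it also remains open whether configuration would matter with chloro on the double-bonded ring carbon, and what an amine or a carboxylic acid at that carbon would do.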